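The source may report more compounds than this note shows. Statements on the series, on what has been measured and on what is new or still open speak of the compounds shown alone.

Within the data shown here, in an ADME assay on L02 cells (Homo sapiens) for inhibition, read by CCK-8 assay, with a stated time of 48 h (a lower number here means a stronger inhibitor of growth, a higher number a weaker inhibitor of growth), compound 1 `CN1CCN(c2ccc(Nc3ncc(Cl)c(NCc4ccc(C(F)(F)F)cc4)n3)nc2)CC1` gives 26200 nM and compound 2 `Cc1cccc(Nc2nc(Nc3ccc(N4CCN(C)CC4)cn3)ncc2Cl)c1` gives 6080 nM, the lower of the two numbers so far. Compound 3 `CC(C)c1ccc(Nc2nc(Nc3ccc(N4CCN(C)CC4)cn3)ncc2Cl)cc1` keeps the shared core and carries 4-isopropylphenyl in place of 3-methylphenyl on a nitrogen on an aromatic ring. Among the measured compounds shown here, only one measured step bears on this, a 4.3-fold lower number from compound 1 to compound 2 (0.63 log units; beyond the scatter), a modest step that came with 3-methylphenyl replacing 4-(trifluoromethyl)benzyl at the same place. That step involved a different departing group, so it is only a loose guide. The new exchange swaps one carbon-only aromatic group for another, and no step beyond the scatter is expected in this assay, with no firm direction. For compound 3 the estimated value is 5000 nM, with an expected range from 1800 nM to 14000 nM. This estimate amounts to an expected 1.2-fold lower number from compound 2 to compound 3 (0.08 log units; within the scatter).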

Compound 3, concentration for 50% growth inhibition: 13700 nM
The estimate for compound 3 lay 2.7-fold (0.44 log units) below the measured number, and the stated range covers the measured number.
By their numbers in this assay, from the lowest: compound 2; then compounds 3 and 1 (each within the scatter of the next).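

In this assay, exchanging one carbon-only aromatic group for another on this nitrogen does change the number: a 2.3-fold higher number from compound 2 to compound 3 (0.35 log units; beyond the scatter), even though 3-methylphenyl and 4-isopropylphenyl each hold one six-membered aromatic ring of carbon only and no hydrogen-bond donors or acceptors. By contrast, a 1.9-fold lower number from compound 1 to compound 3 (0.28 log units; within the scatter), which lies within the scatter, so 4-isopropylphenyl and 4-(trifluoromethyl)benzyl cannot be ordered here. The separation seen earlier between compound 1 and compound 2 therefore does not extend to every aromatic group at this place.

The compounds shown do not separate where the ring substituent sits from what it is, since 3-methylphenyl and 4-isopropylphenyl differ in both, and they leave open how a phenyl ring carrying an amine or a carboxylic acid would read in this assay. No measured property of these groups is available to account for these steps.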